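Halogenated benzamides: from compound 3 to compound 4

The source may report more compounds than this note shows. Statements on the series, on what has been measured and on what is new or still open speak of the compounds shown alone.

Three amides on the shared core have numbers in a functional assay on HEK293 cells for agonist activity at D(4) dopamine receptor (Homo sapiens), read by FLIPR; on this read-out higher numbers stand for larger maximal responses and lower numbers for smaller maximal responses. Compound 1 `Cc1ccc(C(=O)NCN2CCC(c3cccc[n+]3[O-])CC2)cc1C` gives 65%. Within the data shown here, compound 2 `C=Cc1cccc(C(=O)NCN2CCC(c3cccc[n+]3[O-])CC2)c1` gives 63%, and the step of a number 2 percentage points lower from compound 1 to compound 2 (within the scatter) is the only measured change of the aryl group. Compound 3 `O=C(NCN1CCC(c2cccc[n+]2[O-])CC1)c1ccc(OC(F)(F)F)c(Cl)c1` gives 33%, the lowest of the three; compound 2 at 63% and compound 1 at 65% both stand beyond the scatter above it.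

Compound 4 `O=C(NCN1CCC(c2cccc[n+]2[O-])CC1)c1ccc(F)c(Cl)c1` is not yet measured in this assay. It differs from compound 3 by fluoro in place of trifluoromethoxy on an aromatic carbon. Among the measured compounds shown here, no measured step swaps trifluoromethoxy for fluoro, and the one measured aryl step, a number 2 percentage points lower from compound 1 to compound 2 (within the scatter), concerns other groups on an otherwise unsubstituted ring and was within the scatter. The data therefore give no basis for a direction; the working expectation is a step of a number 7 percentage points higher from compound 3 to compound 4 (within the scatter), within the scatter, carrying a wide range. Compound 4 is estimated at 40%, with a range from 22% to 62%.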

Compound 4, largest response reached (reported as efficacy), in percent of the reference or control that the assay uses: 67%
Compound 4: the middle estimate sits 27 percentage points below what was measured, and the stated range ends below it.
By their numbers in this assay, from the lowest: compound 3; then compounds 2, 1 and 4 (each within the scatter of the next).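

In this assay, the step of a number 34 percentage points higher from compound 3 to compound 4 (beyond the scatter) shows that this position, ortho to a chloro group and para to a large group, strongly affects the maximal response, with the chloro group unchanged across the pair. Against the other aryl amides, the steps of a number 4 percentage points higher from compound 2 to compound 4 (within the scatter) and a number 2 percentage points higher from compound 1 to compound 4 (within the scatter) show that the chloro group does not by itself go with the low number of compound 3. Nothing available explains the large step.

The compounds shown leave open whether the low number is specific to trifluoromethoxy or would also appear with methoxy, trifluoromethyl or a nitrile at this position. They also leave open whether fluoro gives a similar response without the chloro group, and how an amine would behave here.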